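One Methoxy Swap, Measured Once, Expected Again

This account rests on a few compounds, and the source may have more. Where it says the series, first, only, none or still open, it means among the compounds named here.

The measured compounds:
Compound 1, `COc1cc(C(=O)c2ccc3c(ccn3S(=O)(=O)c3ccc(/C=C/C(=O)NO)cc3)c2)cc(OC)c1OC`, gives 5340 nM in an assay on isolated protein for inhibition of histone deacetylase 8 (Homo sapiens); on this read-out lower numbers stand for stronger inhibition and higher numbers for weaker inhibition.
Compound 2, `COc1ccc(C(=O)c2ccc3c(ccn3S(=O)(=O)c3ccc(/C=C/C(=O)NO)cc3)c2)cc1`, gives 10000 nM in this assay.
Compound 3, `COc1cc(C(=O)c2ccc3c(ccn3Cc3ccc(/C=C/C(=O)NO)cc3)c2)cc(OC)c1OC`, gives 2170 nM in this assay.

Compound 1 and compound 2 share a core and differ in one place: 4-methoxyphenyl in place of 3,4,5-trimethoxyphenyl on a carbonyl carbon. That change produced a 1.9-fold higher number from compound 1 to compound 2 (0.27 log units; within the scatter), so the two values cannot be ranked against each other. Compound 3 has a different core from compound 1, and that difference is not broken down here. Compound 3 gives the lowest of the three numbers, and its gaps to compound 1 and to compound 2 both lie beyond the scatter.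

Compound 4, `COc1ccc(C(=O)c2ccc3c(ccn3Cc3ccc(/C=C/C(=O)NO)cc3)c2)cc1`, has not yet been measured. It differs from compound 3 in one place: 4-methoxyphenyl in place of 3,4,5-trimethoxyphenyl on a carbonyl carbon. The place is described in the same words as for the earlier pair, so this is the same change. Among the compounds with values here, the step from compound 3 to compound 4 is expected to be about a 1.9-fold higher number from compound 3 to compound 4 (0.28 log units; within the scatter), set beside the earlier step because a 1.9-fold higher number from compound 1 to compound 2 (0.27 log units; within the scatter) is the only measured instance of this change. Compound 4 is therefore expected to give around 4100 nM in this assay. With a single supporting step, the estimated range runs from 1800 nM to 9500 nM.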

Compound 4, half-maximal inhibitory concentration: 2810 nM
Beside the measured number, compound 4's estimate is 1.5-fold (0.16 log units) above it; the range from low to high includes it.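

In this assay, putting 4-methoxyphenyl in place of 3,4,5-trimethoxyphenyl on a carbonyl carbon gave a 1.3-fold higher number from compound 3 to compound 4 (0.11 log units; within the scatter), so the two values in this new pair cannot be ranked against each other. The same change has now been seen on two cores, and the two steps cannot be told apart: the same change on two cores in this assay, a 1.9-fold higher number (0.27 log units; within the scatter) from compound 1 to compound 2 and a 1.3-fold higher number (0.11 log units; within the scatter) from compound 3 to compound 4, 1.4-fold (0.16 log units) apart, within the scatter of two such steps. This shows that the change left no readable difference on either of these two cores, but it does not show that the change has a real effect of any size, nor that it would behave the same way on a third core.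

The compounds shown leave open what a clearly different group on the carbonyl carbon would do, such as one carrying an amine or a carboxylic acid in place of the methoxy groups. They also leave open whether this change would stay as small in any assay other than this assay.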